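A few compounds are considered here, and "the series" means these few. Any claim that something is new, unique, unknown or untested is made for them only; others in the source may bear on it.

Going by the values given here, compound 2 `CC1(C)[C@H]2CC[C@]1(C)N(Cc1cn(-c3cccc(C#N)c3)nn1)C(=O)C2` stands at the lower of the two numbers so far in a functional assay on HepG2 cells (Homo sapiens) for inhibition, read by MTT assay, with a stated time of 24 h (a lower number here means a stronger inhibitor, a higher number a weaker inhibitor), giving 40 nM; compound 1 `CC1(C)[C@H]2CC[C@]1(C)N(Cc1cn(-c3ccccc3Br)nn1)C(=O)C2` gives 150 nM, and the step of a 3.8-fold lower number from compound 1 to compound 2 (0.57 log units; beyond the scatter) is the only one measured. Compound 3 `CC1(C)[C@H]2CC[C@]1(C)N(Cc1cn(-c3ccc(O)cc3)nn1)C(=O)C2` carries 4-hydroxyphenyl in place of 3-cyanophenyl on an aromatic nitrogen. Among the compounds with values here, the measured step swaps one aryl group for another on the same aromatic nitrogen and moves the number modestly, but no measured step sets a hydroxyl against a nitrile. A step of comparable size in either direction is therefore plausible; the estimate leans towards a somewhat higher number, a 2.0-fold higher number from compound 2 to compound 3 (0.30 log units; within the scatter). Compound 3 is expected to give 80 nM, within 25 nM to 250 nM.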

Compound 3, half-maximal inhibitory concentration: 80 nM
The estimate for compound 3 equals the measured number at the digits printed; measured number inside the range.
By their numbers in this assay, from the lowest: compounds 2, 3 and 1 (each within the scatter of the next, the first and the last beyond it).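

In this assay the aromatic nitrogen also accepts 4-hydroxyphenyl, which brings a hydrogen-bond donor, with a 2.0-fold higher number from compound 2 to compound 3 (0.30 log units; within the scatter) and a 1.9-fold lower number from compound 1 to compound 3 (0.27 log units; within the scatter). Compound 3 therefore cannot be separated from either neighbour, although compound 1 and compound 2 are separated from each other. No accompanying measurement bears on the reason for these numbers.

Open, from the compounds shown here alone, is whether an amine or a carboxylic acid on this phenyl ring would stay in the same range. Also open, going by these compounds, is whether 3-hydroxyphenyl or 4-cyanophenyl would give the numbers of their counterparts.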